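The source may hold more compounds than are shown below. What is called first, only, known or untested is meant among the compounds shown, and "the series" means these compounds.

Measured compounds in a functional assay on A549 cells (Homo sapiens) for cytotoxicity; on this read-out lower numbers stand for an effect already at smaller amounts and higher numbers for an effect only at larger amounts of compound:
Compound 1, `C=CCCCCCCCC#CC#C/C=C\C(C)=O`, gives > 50 ug/mL, which is a limit of the assay and not a number.
Compound 2, `CCCCCCCC#CC#C/C=C\C(C)=O`, gives > 50 ug/mL, again a limit.
Compound 3, `CCCCCCCC#CC#CC1CC(=O)C=C(C)C1`, gives > 50 ug/mL, also a limit.

Compound 1 therefore stands at the limit of this assay, together with the other two measured compounds: the limit of > 50 ug/mL in this assay, at which 3 of the 3 values shown sit. Among the compounds with values here, the only step that joins two measured compounds differing in one place, a step that the two limits leave unreadable from compound 1 to compound 2, cannot be read in size, since both of its ends sit at the limit. Compound 3 shows the same limit as compound 1 and compound 2 and adds nothing that can be ordered.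

Compound 4, `C=CCCCCCCCC#CC#C/C=C/C(C)=O`, has not been measured in this assay. Its change from compound 1 is the two compounds have the same atoms and bonds and differ only in configuration as drawn: 1 of 1 stereo elements differ; a double bond is drawn Z in compound 1 and E in compound 4. Within the data shown here, no measured step bears on a change of this kind, and the one step that exists is unreadable. None of the three values shows an effect inside the measured window, so compound 4 is expected to remain at or near the limit. The step from compound 1 to compound 4 that this implies, a step that the limit leaves unreadable from compound 1 to compound 4, is estimated to lie within the scatter. For compound 4 the estimate is 70 ug/mL, with a range from 30 ug/mL to 200 ug/mL, and the assay is expected most likely to report only a limit again.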

Compound 4, concentration for half-maximal effect: > 50 ug/mL
Compound 4: only a limit was reported (the forecaster's own chance of this, stated with the estimate: 80%); the middle value is on the limit's open side.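

In this assay compound 4 gives > 50 ug/mL, which is a limit and not a number. The step between compound 1 and compound 4 cannot be read, as both sit at the same limit: the limit of > 50 ug/mL in this assay, at which 4 of the 4 values shown sit.

The compounds shown leave open whether the Z or E double bond matters at all, and what structure would give a readable value in this assay.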